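The source may report more compounds than this note shows. Statements on the series, on what has been measured and on what is new or still open speak of the compounds shown alone.

Measured in a functional assay on HL-60 cells (Homo sapiens), with a stated time of 2 days; on this read-out lower numbers stand for stronger inhibition and higher numbers for weaker inhibition:
compound 1 `CCCCCCNC(=O)c1[nH]cnc1C(=O)Nc1ccc(Cl)c(Cl)c1`: 14600 nM
compound 2 `O=C(NCc1ccc(-c2ccccc2)cc1)c1nc[nH]c1C(=O)Nc1ccc(Cl)c(Cl)c1`: 7000 nM

Of these two compounds, compound 1 has the higher number, at 14600 nM, so it is the weaker inhibitor in this assay. Compound 2 gives 7000 nM. The gap between the two compounds lies beyond the scatter, with compound 2 on the stronger side.

The next compound to be measured is compound 3 `C[C@H](NC(=O)c1[nH]cnc1C(=O)Nc1ccc(Cl)c(Cl)c1)c1ccccc1`. It keeps the core of compound 1 but has 1-phenylethyl in place of hexyl on an amide-type nitrogen. Among the measured compounds shown here, no measured pair isolates this change, so the expectation rests on two values only. Compound 2, with aromatic rings in its amide substituent, reads 7000 nM, and this suggests at most a small fall in the number, probably within the scatter. The expected change is a 1.3-fold lower number from compound 1 to compound 3 (0.12 log units; within the scatter). For compound 3 the estimated value is 11000 nM, with an expected range of 5000 nM to 25000 nM.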

Compound 3, half-maximal inhibitory concentration: 9200 nM
Estimate against measurement, compound 3: 1.2-fold (0.08 log units) above; low and high end bracket the measured number.
By their numbers in this assay, from the lowest: compounds 2, 3 and 1 (each within the scatter of the next, the first and the last beyond it).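

In this assay, among the compounds shown here, the swap of hexyl for 1-phenylethyl on an amide-type nitrogen gives a 1.6-fold lower number from compound 1 to compound 3 (0.20 log units; within the scatter) and is the first pair in which this place alone differs, with the core of compound 1 held constant. It shows that an open chain and a group carrying a six-membered aromatic ring and a defined stereocentre cannot be told apart at this position in this read-out. Nothing shown gives a reason for this result.

On these data alone, whether the mirror-image form of 1-phenylethyl, a plain benzyl, or a hexyl chain ending in an amine or a carboxylic acid would read differently at this nitrogen stays open. So does whether the same swap would read alike in any other kind of test.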